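Sulfonyl and carbonyl caps on the shared core

The compounds below may be only part of what the source reports. "The series", "measured", "known", "first", "only" and "open" are said of these compounds alone.

Measured in a functional assay on A-375 cells (Homo sapiens) for cytotoxicity, read by MTT assay; a lower number here means a stronger inhibitor, a higher number a weaker inhibitor:
- compound 1 `O=S(=O)(NCCNc1nccc(-c2c(-c3cccc(F)c3)nc3sccn23)n1)c1ccc(Br)cc1`: 13500 nM
- compound 2 `O=S(=O)(NCCNc1nccc(-c2c(-c3cccc(F)c3)nc3sccn23)n1)c1ccc(C(F)(F)F)cc1`: 7440 nM
- compound 3 `O=C(NCCNc1nccc(-c2c(-c3cccc(F)c3)nc3sccn23)n1)c1ccc(C(F)(F)F)cc1`: 8710 nM

Compound 3 gives the second highest of the three numbers; compound 2 is nearest and compound 1 furthest, and both gaps lie within the scatter. Compound 4 `O=S(=O)(NCCNc1nccc(-c2c(-c3cccc(F)c3)nc3sccn23)n1)c1ccccc1` keeps the shared core and differs only in the cap: phenylsulfonyl in place of (4-(trifluoromethyl)phenyl)carbonyl on an amine nitrogen. For the measured compounds named here, two measured steps bear on this. The cap exchange a 1.5-fold lower number from compound 1 to compound 3 (0.19 log units; within the scatter) stayed within the scatter, as did the substituent exchange a 1.8-fold lower number from compound 1 to compound 2 (0.26 log units; within the scatter). Neither gives a reason to expect movement beyond the scatter in this assay , so the step of a 1.1-fold higher number from compound 3 to compound 4 (0.06 log units; within the scatter) is expected to be small. Compound 4 is therefore estimated at 10000 nM, with a range of 4000 nM to 25000 nM.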

Compound 4, half-maximal inhibitory concentration: 11000 nM
The estimate for compound 4 lay 1.1-fold (0.04 log units) below the measured number; low and high end bracket the measured number.
By their numbers in this assay, from the lowest: compounds 2, 3, 4 and 1 (each within the scatter of the next).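

In this assay hydrogen in place of trifluoromethyl gives a 1.5-fold higher number from compound 2 to compound 4 (0.17 log units; within the scatter) and hydrogen in place of bromo gives a 1.2-fold lower number from compound 1 to compound 4 (0.09 log units; within the scatter) so the unsubstituted cap cannot be told apart from either substituted sulfonyl cap. Phenylsulfonyl in place of (4-(trifluoromethyl)phenyl)carbonyl gives a 1.3-fold higher number from compound 3 to compound 4 (0.10 log units; within the scatter) and this exchange of the whole cap also stays inside the scatter. No available evidence accounts for these steps.

The compounds shown leave open whether an amine or a carboxylic acid on the cap's aromatic ring, or a longer chain on the amine nitrogen, would move the number beyond the scatter.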